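A few compounds are considered here, and "the series" means these few. Any claim that something is new, unique, unknown or untested is made for them only; others in the source may bear on it.

Working notes on a short series sharing one core, all read in a functional assay on the whole organism (strain Sprague-Dawley CD) for inhibition, with Rattus norvegicus as the target, read by paw edema, at a dose of 30 mg/kg by the intraperitoneal route; on this read-out higher numbers stand for a stronger effect at the one dose given and lower numbers for a weaker effect. Compound 1 `CCOC(=O)C(=O)Nc1c(C)ccccc1=O` gives 47%. Compound 2 `CCOC(=O)C(=O)Nc1ccccc(C)c1=O` gives 60%, the highest of the three numbers; compound 1 sits below it by a margin beyond the usual scatter. Compound 3 `CCOC(=O)C(=O)Nc1ccccc(N(C)S(=O)(=O)c2ccc(C)cc2)c1=O` gives 32%, the furthest from compound 2 and also beyond the scatter.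

Compound 4 `CCOC(=O)C(=O)Nc1ccccc(-c2ccccc2)c1=O` has not been measured. It differs from compound 2 in one place: phenyl in place of methyl on an aromatic carbon. Going by the values given here, no pair of measured compounds shows this same change, so the only guide is that compound 3, which carries a larger group at that same place, stands lowest of the three. In this assay a decrease beyond the scatter is expected, a number 20 percentage points lower from compound 2 to compound 4 (beyond the scatter), because compound 3 with its group of 8 heavy atoms at that place gives 32%. Compound 4 is estimated at 40%, with a range from 25% to 56%.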

Compound 4, a percentage reported as inhibition, in the whole organism at one dose (the size of the read-out at that dose, not a potency): 72%
The estimate for compound 4 lay 32 percentage points below the measured number; the whole stated range lies below it.
By their numbers in this assay, from the lowest: compound 3; then compound 1; then compound 2; then compound 4.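

At this place, on an aromatic carbon of a seven-membered aromatic ring of carbon only, phenyl in place of methyl gives a number 12 percentage points higher from compound 2 to compound 4 (beyond the scatter) in this assay. The number of heavy atoms at this place therefore does not set the order on its own: compound 3, which also carries a larger group here, gives 32%, whereas compound 4 gives 72%. Nothing at hand accounts for the rise from methyl to phenyl.

Going by these compounds, whether the rise needs an aromatic ring stays open: a cyclohexyl ring or a longer alkyl chain at this place would separate ring type from carbon count. Also open, on these data alone, is how a phenyl carrying a methoxy group or a carboxylic acid would read, and whether phenyl gives a like step at the place methyl holds in compound 1.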